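The source may report more compounds than this note shows. Statements on the series, on what has been measured and on what is new or still open speak of the compounds shown alone.

Measured so far:
Compound 1 `COc1cc2c(Oc3ccc(NC(=O)c4nnn(-c5ccccc5)c4C)cc3F)ccnc2cc1OCCCN1CCCC1` gives 130 nM in a functional assay on HT-29 cells (Homo sapiens) for cytotoxicity, read by MTT assay, with a stated time of 72 h; on this read-out higher numbers stand for weaker inhibition and lower numbers for stronger inhibition.
Compound 2 `COc1cc2c(Oc3ccc(NC(=O)c4nnn(-c5ccccc5C)c4C)cc3F)ccnc2cc1OCCCN1CCCCC1` gives 450 nM in this assay.

Compound 2 carries the highest number of the two in this assay; its nearest neighbour is compound 1, whose number is lower by a margin that lies beyond the scatter. The two compounds differ in two places at once, in the aryl group on the triazole and in the amine at the end of the chain, so the two values alone do not tell which change carries the gap.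

Compound 3 `COc1cc2c(Oc3ccc(NC(=O)c4nnn(-c5ccccc5)c4C)cc3F)ccnc2cc1OCCCN1CCCCC1` is not yet measured in this assay. It differs from compound 2 in one place only: hydrogen in place of methyl on an aromatic carbon, that is, 2-methylphenyl becomes phenyl, while the amine at the chain end stays as in compound 2. Going by the values given here, no measured pair shows this change alone. Compound 1, which also carries the plain phenyl, sits lower in this assay, and so a moderate downward step is expected for compound 3, though part of the gap to compound 1 may belong to the amine instead. The step from compound 2 to compound 3 is estimated at a 2.0-fold lower number from compound 2 to compound 3 (0.31 log units; beyond the scatter). For compound 3 the expected value is 220 nM, within 80 nM to 550 nM.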

Compound 3, half-maximal inhibitory concentration: 120 nM
Beside the measured number, compound 3's estimate is 1.8-fold (0.26 log units) above it; the measured number falls inside the stated range.
By their numbers in this assay, from the lowest: compounds 3 and 1 (each within the scatter of the next); then compound 2.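

In this assay, going by these compounds alone, the loss of the methyl group ortho to a large group, with the piperidin-1-yl at the chain end held fixed, brings a 3.8-fold lower number from compound 2 to compound 3 (0.57 log units; beyond the scatter) and so gives the first reading of the change from 2-methylphenyl to phenyl on its own. With the phenyl held fixed, the exchange of pyrrolidin-1-yl for piperidin-1-yl at the end of the chain gives a 1.1-fold lower number from compound 1 to compound 3 (0.03 log units; within the scatter) and thus stays within the scatter, so these two amines cannot be told apart in this assay when the aryl group is plain phenyl. Nothing measured here explains why the methyl group on this ring goes with the higher number.

From the compounds shown here alone, because the methyl step has been read only with piperidin-1-yl at the chain end, it remains open whether the same step would appear with pyrrolidin-1-yl there. Also open, going by these compounds, is how other groups would read at this aromatic carbon, such as a methoxy group, a chlorine or a fluorine, and how a morpholine or a dimethylamino group at the end of the chain would compare.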